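Dipropylamino replacement on the aryl amine of the sulfamate series

The source may hold more compounds than are shown below. What is called first, only, known or untested is meant among the compounds shown, and "the series" means these compounds.

Compound 1 `CCN(Cc1ccccn1)c1cccc(C(=O)N2CCc3ccc(OS(N)(=O)=O)cc3C2)c1` is the reference point for this note. In an assay on HEK293 cells for inhibition of Steryl-sulfatase (Homo sapiens), tested at 0.1 uM (a higher number here means a stronger effect of the compound at the concentration tested, a lower number a weaker effect), compound 1 gives 6.5%, the lowest of the three numbers in hand. Compound 3 `NS(=O)(=O)Oc1ccc2c(c1)CN(C(=O)c1cccc(N(Cc3ccccc3)Cc3ccco3)c1)CC2` gives 27.5% in this assay, the nearest number to compound 1 but still beyond the scatter above it. Compound 2 `CC(C)CCN(CCC(C)C)c1ccc(C(=O)N2CCc3ccc(OS(N)(=O)=O)cc3C2)cc1` gives 47% in this assay, the furthest of the three from compound 1 and again beyond the scatter. No two of the measured compounds differ in one place, so no single step can be read from them.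

Compound 4 `CCCN(CCC)c1cccc(C(=O)N2CCc3ccc(OS(N)(=O)=O)cc3C2)c1` is not yet measured. Its change from compound 1 is dipropylamino in place of ethyl((pyridin-2-yl)methyl)amino on an aromatic carbon. An upward step beyond the scatter is expected, a number 18.5 percentage points higher from compound 1 to compound 4 (beyond the scatter), because compound 2 gives 47% and compound 3 gives 27.5% in this assay, both well above compound 1. Compound 4 is estimated at 25%, within a range from 10% to 45%.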

Compound 4, a percentage reported as inhibition, at one concentration (the size of the read-out at that concentration, not a potency): 8.3%
Compound 4: the middle estimate sits 16.7 percentage points above what was measured; measured number outside the range, below it.
By their numbers in this assay, from the lowest: compounds 1 and 4 (each within the scatter of the next); then compound 3; then compound 2.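

In this assay, dipropylamino in place of ethyl((pyridin-2-yl)methyl)amino gives a number 1.8 percentage points higher from compound 1 to compound 4 (within the scatter), so this change on an aromatic carbon, meta to a large group, does not separate the two compounds. At this position, the six-membered aromatic ring with its hetero atom can therefore give way to an open dipropylamino group with no change in the read-out beyond the scatter. No measured evidence bears on why the two groups read alike.

Steps linking compound 2 or compound 3 to the other compounds cannot be read, since each differs from them in more than one place, and what sets their values apart stays open. Also open, as far as these compounds go, is whether a morpholine or a longer chain such as dipentylamino at this same position would move the read-out beyond the scatter.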